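Nitro to cyano on the phenacyl thioether arm

The source may report more compounds than this note shows. Statements on the series, on what has been measured and on what is new or still open speak of the compounds shown alone.

Measured so far:
Compound 1, `CCOC(=O)c1ccc(Nc2ccnc(SCC(=O)c3ccc([N+](=O)[O-])cc3)n2)cc1`: 19%
Compound 2, `COc1ccc(C(=O)CSc2nccc(Nc3cccc(C(C)=O)c3)n2)cc1`: 11%

Both compounds share one core and were tested in a functional assay on HT-29 cells (Homo sapiens) for inhibition, read by sulforhodamine B assay, with a stated time of 48 h, tested at 10 uM; on this read-out lower numbers stand for less inhibition of growth and higher numbers for more inhibition of growth at the one concentration tested. Compound 1 gives 19%, the higher of the two numbers, and compound 2 gives 11%; the gap between them lies within the scatter, so the two stand as much the same, and neither can be called the more active. Within the data shown here, no pair differing in one place has been measured, so no step size is known from the data itself.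

Compound 3, `CCOC(=O)c1ccc(Nc2ccnc(SCC(=O)c3ccc(C#N)cc3)n2)cc1`, follows from compound 1 by a single change: cyano in place of nitro on an aromatic carbon. Nothing measured here shows what such a change does to growth inhibition, and with two compounds of weak and indistinguishable inhibition no direction can be read off. The expected step from compound 1 to compound 3 in this assay is therefore small, a number 4 percentage points lower from compound 1 to compound 3 (within the scatter), and is not expected to exceed the scatter in either direction.

Compound 3 is estimated at 15%, in a range from 0% to 35%.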

Compound 3, percent growth inhibition at one concentration: 24%
Compound 3: middle estimate off by 9 percentage points, on the low side; low and high end bracket the measured number.
By their numbers in this assay, from the lowest: compounds 2, 1 and 3 (each within the scatter of the next, the first and the last beyond it).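

Among these compounds, the change from 4-nitrophenyl to 4-cyanophenyl, on an aromatic carbon para to a large group, gives in this assay a number 5 percentage points higher from compound 1 to compound 3 (within the scatter) and supplies the first step read from a pair of compounds that differ in one place. At this position on the phenacyl thioether arm, the nitro group with its 3 heavy atoms can thus give way to the cyano group with its 2 heavy atoms without a step beyond the scatter, so a nitro group is not needed here for the weak growth inhibition seen at the one concentration tested. No available evidence bears on the reason for this step or on what either group contributes.

Going by these compounds, what a primary amine, a carboxylic acid or a longer alkyl chain would give on this same aromatic carbon remains open, as does whether any replacement here can produce a step beyond the scatter. Also open, on these data alone, is whether cyano in place of nitro gives a similar step when the ethyl ester on the other arm of the shared core is replaced by an amide or a carboxylic acid.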